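This account rests on a few compounds, and the source may have more. Where it says the series, first, only, none or still open, it means among the compounds named here.

Of the compounds shown here, three have been tested so far in a functional assay with Mus musculus as the target; a lower number here means that less compound is needed, a higher number that more compound is needed for the effect. Compound 1 `C=CCn1c(=O)n(CCCCO)c2nc(N)nc(O)c21` gives 52 uM. Compound 2 `NC(=O)Cn1c(=O)n(C2OC(CO)[C@@H](O)[C@H]2O)c2nc(N)nc(O)c21` gives 117 uM, the highest of the three numbers, which means it needs the most material for the effect. Compound 3 `C=CCn1c(=S)n(COCCO)c2nc(N)nc(O)c21` gives 13 uM, the lowest of the three. Compound 2 is the starting point for a new analogue, compound 4 `Cn1c(=O)n(C2OC(CO)[C@@H](O)[C@H]2O)c2nc(N)nc(O)c21`. The change is hydrogen in place of carbamoyl on a saturated chain carbon bound to an aromatic nitrogen. Within the data shown here, nothing among the measured compounds shows this exact swap, so the size of its effect can only be guessed. The step from compound 2 to compound 4 is expected to be small, a 1.3-fold lower number from compound 2 to compound 4 (0.11 log units; within the scatter), likely within the scatter or a modest move toward less material needed. Compound 4 is therefore estimated at 90 uM, with a plausible range from 30 uM to 300 uM.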

Compound 4, concentration for half-maximal effect: 120 uM
Compound 4: the middle estimate sits 1.3-fold (0.12 log units) below what was measured; the measured number falls inside the stated range.
By their numbers in this assay, from the lowest: compound 3; then compound 1; then compounds 2 and 4 (each within the scatter of the next).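

Among these compounds, the step of a 1.0-fold higher number from compound 2 to compound 4 (0.01 log units; within the scatter) in this assay is the first direct reading of a change at this place, on a saturated chain carbon bound to an aromatic nitrogen. With the rest of the structure held constant, carbamoylmethyl and methyl cannot be told apart here, so this pair gives no sign that the carbamoyl group matters for this read-out. Nothing available explains this result. Going by these compounds, whether a carboxylic acid or an amine at this place would also leave the number within the scatter stays open, as does whether carbamoyl behaves the same way in compounds built like compound 1 or compound 3.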